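The compounds below may be only part of what the source reports. "The series", "measured", "known", "first", "only" and "open" are said of these compounds alone.

Working notes on the series. Compound 2 `CC(C(=O)N1CCN(c2cccc(C(F)(F)F)c2)CC1)N1C(=O)CCC1=O` gives 100% in a functional assay on the whole organism (strain Swiss) with Mus musculus as the target, in the maximal electroshock model, with a stated time of 1 h, at a dose of 300 mg/kg by the intraperitoneal route (a lower number here means a weaker effect, a higher number a stronger effect of the compound at the dose given), the highest of the two numbers in hand; compound 1 `CCC(C(=O)N1CCN(c2cccc(C)c2)CC1)N1C(=O)CCC1=O` gives 75% in this assay, a number that lies beyond the scatter below it. Compound 3 `Cc1cccc(N2CCN(C(=O)C(C)N3C(=O)CCC3=O)CC2)c1` is not yet measured in this assay; it differs from compound 2 by methyl in place of trifluoromethyl on an aromatic carbon. Among the measured compounds shown here, no measured pair in the set shows this change on its own, so the step is expected to be a modest loss, about a number 15 percentage points lower from compound 2 to compound 3 (beyond the scatter), possibly beyond the scatter. For compound 3 the estimate in this assay is 85%, with a range from 60% to 100%.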

Compound 3, a percentage reported as activity, at one dose (the size of the read-out at that dose, not a potency): 0%
Compound 3: the middle estimate sits 85 percentage points above what was measured, and the stated range ends above it.
By their numbers in this assay, from the lowest: compound 3; then compound 1; then compound 2.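

Methyl in place of trifluoromethyl on an aromatic carbon gives a number 100 percentage points lower from compound 2 to compound 3 (beyond the scatter) in this assay, so the read-out at this ring position depends strongly on which of these two groups it carries. Aromatic methyl alone does not settle the outcome: hydrogen in place of methyl on the saturated chain carbon gives a number 75 percentage points lower from compound 1 to compound 3 (beyond the scatter), so the two positions have to be read together. Nothing available bears on the cause of either step. Open remain how chlorine or a methoxy group on that aromatic carbon would read, and what a longer chain on the saturated carbon would do.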